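Cytotoxicity of a chromone amide series: a methoxyphenyl variant

This account rests on a few compounds, and the source may have more. Where it says the series, first, only, none or still open, it means among the compounds named here.

Measured compounds:
Compound 1 `COc1ccc2c(=O)c(/C=C/C(=O)Nc3cccc(C)c3)coc2c1` — 554000 nM
Compound 2 `COc1ccc2c(=O)c(/C=C/C(=O)NCc3ccc(F)cc3)coc2c1` — 133000 nM
Compound 3 `COc1ccc2c(=O)c(/C=C/C(=O)NCc3ccccc3F)coc2c1` — 146000 nM

Of the compounds shown here, three sharing one core have been tested in an ADME assay on HepG2 2.2.15 cells (Homo sapiens) for cytotoxicity, read by MTT assay, with stated times of 48 h and 9 days; on this read-out lower numbers stand for higher toxicity in this test and higher numbers for lower toxicity in this test. Compound 1 gives the highest number of the three, so it is the least toxic in this assay: its value lies a 4.2-fold lower number from compound 1 to compound 2 (0.62 log units; beyond the scatter) and a 3.8-fold lower number from compound 1 to compound 3 (0.58 log units; beyond the scatter) apart from the other two. Both of those steps exchange an aromatic ring attached directly to the amide nitrogen for a ring attached through one saturated carbon. Between compound 2 and compound 3 the two values lie within the usual scatter.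

Compound 4 `COc1ccc2c(=O)c(/C=C/C(=O)Nc3ccccc3OC)coc2c1` keeps the aromatic ring directly on the amide nitrogen and changes only what sits on that ring: 2-methoxyphenyl in place of 3-methylphenyl on an amide-type nitrogen.

For the measured compounds named here, no measured step alters only the substituent on such a directly attached ring, so the two measured steps from compound 1 say little about this change; they show that a larger rearrangement of the amide side shifted this assay modestly. With the attachment unchanged, no step beyond the scatter is expected for compound 4, and its estimated value is 420000 nM (range 160000 nM to 900000 nM), which amounts to an expected step of a 1.3-fold lower number from compound 1 to compound 4 (0.12 log units; within the scatter).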

Compound 4, half-maximal cytotoxic concentration: 1050000 nM
For compound 4 the middle estimate is 2.5-fold (0.40 log units) below the measured one; the whole stated range lies below it.
By their numbers in this assay, from the lowest: compounds 2 and 3 (each within the scatter of the next); then compounds 1 and 4 (each within the scatter of the next).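

In this assay, for the compounds shown here, the step of a 1.9-fold higher number from compound 1 to compound 4 (0.28 log units; within the scatter) is the first that changes only the group on a ring attached directly to the amide-type nitrogen, and 2-methoxyphenyl in place of 3-methylphenyl, which adds one oxygen and one hydrogen-bond acceptor, stays within the usual scatter. The other two steps, a 7.2-fold higher number from compound 3 to compound 4 (0.86 log units; beyond the scatter) and a 7.9-fold higher number from compound 2 to compound 4 (0.90 log units; beyond the scatter), both exchange a fluorobenzyl group for 2-methoxyphenyl and are beyond the scatter, so compound 1 and compound 4, with the ring directly on the nitrogen, now both stand apart from the benzyl compounds, compound 2 and compound 3, and none of the four goes against this split. Nothing measured here accounts for that split or gives a reason for it.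

The compounds shown leave open whether the split holds for other groups on the amide-type nitrogen, such as a phenylethyl group with its longer chain. They also leave open how far a ring carrying an amine or a carboxylic acid would keep the number in the range of compound 1 and compound 4.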